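Flipping One Double Bond Where Both Neighbours Sit at a Limit

The compounds below may be only part of what the source reports. "The series", "measured", "known", "first", "only" and "open" are said of these compounds alone.

Measured compounds:
compound 1, `CCCCCCC(C)/C(O)=C1\C(=O)[C@@H]([C@@H](C)O)N(C)C1=O`: > 100000 nM
compound 2, `C/C=C1/C(=O)/C(=C(/O)C(C)CCCCCC)C(=O)N1C`: > 100000 nM

In a functional assay on A549 cells (Homo sapiens) for inhibition, read by MTT assay, with a stated time of 24 h (on this read-out higher numbers stand for weaker inhibition and lower numbers for stronger inhibition), compound 1 gives > 100000 nM. That value for compound 1 is a limit of the assay rather than a number. In this assay compound 2 gives > 100000 nM. For compound 2 this is again a limit, not a measured number. Both measured values rest on (the limit of > 100000 nM in this assay, at which 2 of the 2 values shown sit), so neither compound shows inhibition that the assay can put a number to, and nothing can be said about which of the two is stronger.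

Compound 3, `C/C=C1\C(=O)/C(=C(/O)C(C)CCCCCC)C(=O)N1C`, has not yet been measured. Compared with compound 2, the change is small: the two compounds have the same atoms and bonds; at least one stereo element is drawn with a configuration in one of them and without one in the other: 1 of 3 stereo elements differ; a double bond is drawn Z in compound 2 and E in compound 3. The two compounds share every atom and every bond; only the drawn geometry of one double bond is different. With both known values sitting at the limit, no measurable difference is expected from this change. The expected step is a step that the limit leaves unreadable from compound 2 to compound 3, nothing beyond the usual scatter. Compound 3 is therefore estimated to give about 150000 nM in this assay, within a range from 50000 nM to 500000 nM, and most probably the result will again be reported only as a limit.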

Compound 3, half-maximal inhibitory concentration: > 100000 nM
Compound 3 gave a limit, no number; the forecaster's own chance of this, stated with the estimate: 85%; the middle value does not contradict the limit.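

In this assay compound 3 gives > 100000 nM, again a limit and not a number. Compound 2 also stands at a limit, so no step from it to compound 3 can be read: the limit of > 100000 nM in this assay, at which 3 of the 3 values shown sit.

The compounds shown leave open whether the geometry of this double bond affects inhibition, and at what concentration any of the three compounds would inhibit.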